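Removing the ester entirely from a nitrophenyl amide

This account rests on a few compounds, and the source may have more. Where it says the series, first, only, none or still open, it means among the compounds named here.

Three compounds that share a core and differ only in the ester attached to it have been measured in a functional assay on HepG2 cells (Homo sapiens) for inhibition, read by MTT assay, with a stated time of 72 h; a higher number here means a weaker inhibitor, a lower number a stronger inhibitor. Compound 1 `Cc1ccc(C(=O)OC2(C(=O)Nc3ccc([N+](=O)[O-])cc3)CCCCC2)cc1` gives 61.2 nM. Compound 3 `O=COC1(C(=O)Nc2ccc([N+](=O)[O-])cc2)CCCCC1` gives 34.1 nM, and compound 2 `CCOC(=O)c1ccccc1C(=O)OC1(C(=O)Nc2ccc([N+](=O)[O-])cc2)CCCCC1` gives 517 nM. On these three numbers compound 1 stands second highest: compound 3 is its nearest neighbour, and compound 2 is furthest away, beyond the scatter of this assay.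

Compound 4 `O=C(Nc1ccc([N+](=O)[O-])cc1)C1(O)CCCCC1` is not yet measured. It differs from compound 1 by hydrogen in place of (4-methylphenyl)carbonyl on an oxygen on a saturated carbon, so that the ester is gone and a free hydroxyl remains.

Going by the values given here, one measured step bears on this change. Going a 1.8-fold lower number from compound 1 to compound 3 (0.25 log units; within the scatter), most of the acyl group was cut away and the number did not move beyond the scatter. Compound 4 takes this one step further by removing the remaining carbonyl as well. From that single step, no change beyond the scatter is expected in this assay, though the spread of the three known values leaves room on either side.

Compound 4 is therefore estimated at 60 nM, with a range from 15 nM to 250 nM, which means an expected step of a 1.0-fold lower number from compound 1 to compound 4 (0.01 log units; within the scatter).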

Compound 4, half-maximal inhibitory concentration: 648 nM
The estimate for compound 4 lay 11-fold (1.03 log units) below the measured number, outside the stated range (above it).
By their numbers in this assay, from the lowest: compounds 3 and 1 (each within the scatter of the next); then compounds 2 and 4 (each within the scatter of the next).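

The free hydroxyl does not behave like the esters: in this assay the change gives an 11-fold higher number from compound 1 to compound 4 (1.02 log units; beyond the scatter) and, starting from the smallest ester, a 19-fold higher number from compound 3 to compound 4 (1.28 log units; beyond the scatter). The earlier step from compound 1 to compound 3 had suggested that this oxygen tolerates almost any loss from the acyl group, yet these two steps show that cutting the group down to formyl and removing it altogether are very different changes. Compounds 1 and 3 therefore point to a sharp dependence on keeping some acyl group on this oxygen, although compound 2 goes against any simple rule, since it keeps an acyl group and still has a number within the scatter of that of compound 4, and nothing at hand explains the loss.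

These compounds leave open whether the carbonyl itself is what counts, or whether any capping group on this oxygen would serve as well. A methyl ether, which caps the oxygen without a carbonyl, and an acetyl ester, which keeps the carbonyl with a small methyl group, would begin to separate those two readings.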